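A few compounds are considered here, and "the series" means these few. Any claim that something is new, unique, unknown or untested is made for them only; others in the source may bear on it.

Compound 1, `Cc1cnc(Nc2ccc(Cl)cc2)nc1Nc1nc2ccccc2s1`, > 50000 nM
Compound 2, `NS(=O)(=O)c1ccc(Nc2nccc(Nc3nc4ccc(F)cc4s3)n2)cc1`, 700 nM
Compound 3, `CS(=O)(=O)c1ccc(Nc2ncc(F)c(Nc3nc4ccccc4s3)n2)cc1`, 3270 nM

Of the compounds shown here, three sharing a core have been measured in a functional assay on HCT-116 cells (Homo sapiens) for antiproliferative activity, read by MTT assay, with a stated time of 48 h; a higher number here means a weaker inhibitor, a lower number a stronger inhibitor. Compound 1 gives only > 50000 nM, which is a limit of the assay and not a number; its reading sits at the limit of > 50000 nM in this assay, at which 1 of the 3 values shown sits. Compound 2 gives 700 nM, and compound 3 gives 3270 nM. Compound 1 thus stands at the weak end of the three, with its true value unknown.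

Compound 4, `Cc1cnc(Nc2ccc(S(N)(=O)=O)cc2)nc1Nc1nc2ccccc2s1`, has not yet been measured. It differs from compound 1 in one place: sulfamoyl in place of chloro on an aromatic carbon. Within the data shown here, no step between two measured compounds repeats exactly this exchange, so the size of the step must be guessed. Compound 2 carries the same sulfamoyl group and gives 700 nM. Compound 1 with its chloro gives only a limit. Taken together, this suggests a move toward stronger inhibition.

Compound 4 is expected to reach about 3000 nM, within 500 nM to 30000 nM, which would mean an estimated step of an at least 16-fold lower number from compound 1 to compound 4 (1.22 log units; beyond the scatter).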

Compound 4, half-maximal inhibitory concentration: 1660 nM
For compound 4 the middle estimate is 1.8-fold (0.26 log units) above the measured one; low and high end bracket the measured number.
By their numbers in this assay, from the lowest: compound 2; then compounds 4 and 3 (each within the scatter of the next). At a limit, above all of these: compound 1.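

In this assay, this position on the shared core proves sensitive to what it carries: sulfamoyl in place of chloro, on an aromatic carbon para to a large group, gives an at least 30-fold lower number from compound 1 to compound 4 (1.47 log units; beyond the scatter). This pair is the first among the compounds shown to differ in one place only, so the change can be read directly, free of other differences in the core. The true size of the step stays unknown, because one end of it is a limit and not a number: the limit of > 50000 nM in this assay, at which 1 of the 4 values shown sits.

As far as these compounds go, with only chloro and sulfamoyl seen at this position, it remains open whether an amine or a carboxylic acid there would give a similar number. Also open, from the compounds shown here alone, is which part of the sulfamoyl group matters, for instance whether adding a methyl group to its nitrogen would keep the step.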